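The compounds below may be only part of what the source reports. "The series", "measured", "known", "first", "only" and "open" are said of these compounds alone.

Going by the values given here, compound 3 `C=CC(=O)Nc1cccc(NC(=O)CSc2nc(Nc3ccccc3F)c3ccccc3n2)c1` is one of three compounds measured in a functional assay on MDA-MB-231 cells (Homo sapiens) for inhibition, read by MTT assay, with a stated time of 72 h; on this read-out higher numbers stand for weaker inhibition and lower numbers for stronger inhibition. In this assay compound 3 gives 18700 nM, the second highest of the three numbers; compound 2 `O=C(CSc1nc(Nc2ccccc2)c2ccccc2n1)Nc1ccc([N+](=O)[O-])cc1` gives 16800 nM, within the scatter of that, and compound 1 `O=C(CSc1nc(Nc2ccccc2)c2ccccc2n1)Nc1ccc(F)cc1` gives 34100 nM, also within the scatter. Among the compounds with values here, the only measured step, a 2.0-fold lower number from compound 1 to compound 2 (0.31 log units; beyond the scatter), concerns a different part of the molecule. Compound 4 `C=CC(=O)Nc1cccc(NC(=O)CSc2nc(Nc3cccc(F)c3)c3ccccc3n2)c1` differs from compound 3 by 3-fluorophenyl in place of 2-fluorophenyl on a nitrogen on an aromatic ring. Within the data shown here, no measured step bears on this change, so no step beyond the scatter is expected, and the expected step is a 1.0-fold higher number from compound 3 to compound 4 (0.01 log units; within the scatter). Compound 4 is therefore estimated at 19000 nM, with a range from 9000 nM to 40000 nM.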

Compound 4, half-maximal inhibitory concentration: 8160 nM
The estimate for compound 4 lay 2.3-fold (0.37 log units) above the measured number; measured number below the stated range.
By their numbers in this assay, from the lowest: compound 4; then compounds 2, 3 and 1 (each within the scatter of the next, the first and the last beyond it).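

Placing 3-fluorophenyl in place of 2-fluorophenyl on the nitrogen gives a 2.3-fold lower number from compound 3 to compound 4 (0.36 log units; beyond the scatter) and so shows that, at this position, the number responds to which of these two fluorophenyl groups is present, even though compound 3 and compound 4 have the same atoms. The earlier step concerned a different part of the molecule and could not show this. No measurement available here explains the difference. The compounds shown leave open how 4-fluorophenyl or 3-chlorophenyl on this nitrogen would compare. They also leave open whether this step would hold with another group in place of the rest of compound 4.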